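The source may hold more compounds than are shown below. What is called first, only, known or untested is meant among the compounds shown, and "the series" means these compounds.

Measured in a functional assay on BEAS-2B cells (Homo sapiens) for inhibition, read by MTT assay, with a stated time of 72 h; on this read-out higher numbers stand for weaker inhibition and lower numbers for stronger inhibition:

Compound 1 `C=C(c1ccc(Cl)c(Cl)c1Cl)C1COC2(CCCC2)OO1` gives 11500 nM
Compound 2 `C=C(c1ccc(Cl)cc1Cl)C1COC2(CCCC2)OO1` gives 17400 nM
Compound 3 `C=C(c1ccc(Cl)c(Cl)c1Cl)C1COC(C)(C)OO1` gives 10200 nM

Compound 1 and compound 2 share one core and differ in a single place, (hydrogen in place of chloro on an aromatic carbon). In this assay that change gave a 1.5-fold higher number from compound 1 to compound 2 (0.18 log units; within the scatter), so the two values lie within the usual scatter of each other and no order can be read from them. Compound 3 carries a different core; how the two cores differ is not broken down here. Its value in this assay sits within the scatter of both compound 1 and compound 2.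

Compound 4 `C=C(c1ccc(Cl)cc1Cl)C1COC(C)(C)OO1` is the counterpart of compound 3 on that second core: it differs from compound 3 by hydrogen in place of chloro on an aromatic carbon, which is the same change that leads from compound 1 to compound 2. Because the earlier step was a 1.5-fold higher number from compound 1 to compound 2 (0.18 log units; within the scatter), the step to compound 4 is expected to be small as well, about a 1.5-fold higher number from compound 3 to compound 4 (0.17 log units; within the scatter). Compound 4 is therefore estimated at 15000 nM in this assay, with a likely range from 8000 nM to 30000 nM.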

Compound 4, half-maximal inhibitory concentration: 68600 nM
Estimate against measurement, compound 4: 4.6-fold (0.66 log units) below; the whole stated range lies below it.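

On the core of compound 3, in this assay, hydrogen in place of chloro on an aromatic carbon gave a 6.7-fold higher number from compound 3 to compound 4 (0.83 log units; beyond the scatter) and so moved the number by more than the usual scatter. This change therefore did not carry over at one size from one core to the other: the same change on two cores in this assay, a 1.5-fold higher number (0.18 log units; within the scatter) from compound 1 to compound 2 and a 6.7-fold higher number (0.83 log units; beyond the scatter) from compound 3 to compound 4, 4.4-fold (0.65 log units) apart, beyond the scatter of two such steps. Among these compounds, the comparison rests on only two pairs of compounds, so it shows that the size of this step can depend on the core, but it gives no reason for the gap and no rule for predicting the step on any further core.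

The compounds shown leave open how the number would respond if that aromatic carbon carried something other than chloro or hydrogen, such as a methoxy group or an amine, and whether the two cores would then part in the same way. They also leave open what a longer chain in place of the methyl groups of compound 3 would do to the size of this step.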